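A few compounds are considered here, and "the series" means these few. Any claim that something is new, unique, unknown or untested is made for them only; others in the source may bear on it.

The series shares the core shown in compound 1 `CCOC(=O)CSc1nc(Cl)cc(Nc2ccc3ncccc3c2)n1`, and three of its members have been examined in an assay for inhibition of Polyunsaturated fatty acid 5-lipoxygenase (Homo sapiens), tested at 1 uM; a lower number here means a stronger effect, a higher number a weaker effect of the compound at the concentration tested. Compound 1 gives 86.3%, the higher of the two numbers reported so far. Compound 2 `CCCCCCC(Sc1nc(Cl)cc(Nc2cccc(C)c2C)n1)C(=O)OCC` gives 84.9%, a number that lies within the scatter of compound 1, so no order between the two can be claimed. Compound 3 `Cc1cccc(Nc2cc(Cl)nc(SC(C)C(=O)O)n2)c1C` is reported only as "not active" (no number reported), with no number attached.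

Compound 4 `CCCCC(Sc1nc(Cl)cc(Nc2ccc3ncccc3c2)n1)C(=O)O` has not yet been measured in this assay. It differs from compound 1 in one place: 1-carboxypentyl in place of (ethoxycarbonyl)methyl on a sulfur. Among the measured compounds shown here, no step between measured compounds that share exactly this change is available, so the expectation for compound 4 rests on the general picture, in which compound 1 and compound 2 sit close together and compound 3 is reported without a number. Compound 4 is therefore expected to give about 94%, within a range from 80% to 105%. The step estimated from compound 1 to compound 4 is a number 7.7 percentage points higher from compound 1 to compound 4 (within the scatter), which is expected to stay within the scatter or to lean toward a weaker effect.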

Compound 4, a percentage reported as activity, at one concentration (the size of the read-out at that concentration, not a potency): "not active" (no number reported)
For compound 4 the study gives words and no number; no gap can be computed for the estimate.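

Among the compounds shown here, compound 4 is reported in this assay only in words, and no step from compound 1 to it can be read. No measured evidence bears on this result. The compounds shown leave open how far 1-carboxypentyl and (ethoxycarbonyl)methyl on the sulfur differ in effect.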